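A few compounds are considered here, and "the series" means these few. Any claim that something is new, unique, unknown or untested is made for them only; others in the source may bear on it.

Working notes on the series. Compound 1 `O=C(CCl)N1CCCC(n2nc(-c3ccc(Oc4ccccc4)cc3)cc2CO)C1` is the reference point: in a functional assay on Rec1 cells (Homo sapiens) for inhibition, read by luminescence and CellTiter-Glo, with a stated time of 72 h (a lower number here means a stronger inhibitor, a higher number a weaker inhibitor), compound 1 gives 400 nM, the lowest number among the two measured compounds with a number. Compound 3 `C/C=C/C(=O)Nc1cccc(Cn2nc(-c3ccc(Oc4ccccc4)cc3)cc2CO)c1` gives 3400 nM in this assay, a gap from compound 1 beyond the scatter. For the measured compounds named here, compound 2 `C=CC(=O)Nc1ccc(Cn2nc(-c3ccc(Oc4ccccc4)cc3)cc2C(=O)O)cc1` returns only a limit of the assay, > 60000 nM, and the limit of > 60000 nM in this assay, at which 1 of the 3 values shown sits, records this as the one value that is a limit rather than a number.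

The step under review goes from compound 1 to compound 4 `C/C=C/C(=O)N1CCCC(n2nc(-c3ccc(Oc4ccccc4)cc3)cc2CO)C1`, with the change (prop-1-en-1-yl in place of chloromethyl on a carbonyl carbon). Going by the values given here, no measured pair isolates this change, so its size has to be estimated from the surroundings. Compound 3 carries the same (prop-1-en-1-yl)carbonyl on a different frame and gives 3400 nM, a weaker number than compound 1, which is taken as a hint that the direction is toward a higher number.

Compound 4 is therefore expected to give 1500 nM in this assay, within 500 nM to 5000 nM, a step of a 3.8-fold higher number from compound 1 to compound 4 (0.57 log units; beyond the scatter) that is expected to exceed the scatter.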

Compound 4, half-maximal inhibitory concentration: 27200 nM
Compound 4: the middle estimate sits 18-fold (1.26 log units) below what was measured, outside the stated range (above it).
By their numbers in this assay, from the lowest: compound 1; then compound 3; then compound 4. At a limit, above all of these: compound 2.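

For the compounds shown here, at the carbonyl carbon whose other neighbour is the amide-type nitrogen in a ring, this is the first pair of compounds to isolate a single change, and in this assay prop-1-en-1-yl in place of chloromethyl gives a 68-fold higher number from compound 1 to compound 4 (1.83 log units; beyond the scatter) on an otherwise unchanged structure. The read-out is therefore highly sensitive to the group at this position, and of the two groups compared here, chloromethyl gives the far lower number. The one limit shown belongs to a different compound and does not bear on the size of this step.

Going by these compounds, it remains open whether the step follows from losing the chlorine or from gaining the double bond, a question that a plain ethyl or ethenyl group on the same carbonyl carbon would address. Going by these compounds alone, whether the change has a similar size on other frames also remains open, as only one pair isolates it.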